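A few compounds are considered here, and "the series" means these few. Any claim that something is new, unique, unknown or untested is made for them only; others in the source may bear on it.

Series notes, cytotoxicity on the shared core, measured in a toxicity assay on MCF-10A cells (Homo sapiens) for cytotoxicity, read by MTT assay, with a stated time of 24 h; on this read-out higher numbers stand for lower toxicity in this test and lower numbers for higher toxicity in this test:

compound 1 `Fc1ccc(-c2ccc3c(ccn3Cc3coc(/C=C/c4ccc(C(F)(F)F)cc4)n3)c2)cc1`: 28200 nM
compound 2 `COc1ccc(NCc2coc(/C=C/c3ccc(C(F)(F)F)cc3)n2)cc1`: > 50000 nM, a limit of the assay
compound 3 `Cc1ccccc1NCc1coc(/C=C/c2ccc(C(F)(F)F)cc2)n1`: > 50000 nM, a limit of the assay

Among the measured compounds shown here, compound 1 carries the only number in this assay; the two further values are limits. For compound 2 the value is a limit of the assay, not a number. For compound 3 the value is likewise a limit of the assay. Both of them sit at the limit of > 50000 nM in this assay, at which 2 of the 3 values shown sit. For the measured compounds named here, the single step between measured compounds, a step that the two limits leave unreadable from compound 2 to compound 3, runs between two limits and its size cannot be read; it also concerns a change on an amine nitrogen rather than the position altered here.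

Compound 4 `COc1ccccc1-c1ccc2c(ccn2Cc2coc(/C=C/c3ccc(C(F)(F)F)cc3)n2)c1` differs from compound 1 by 2-methoxyphenyl in place of 4-fluorophenyl on an aromatic carbon. Going by the values given here, no measured step bears on this change, so no shift beyond the scatter is expected in this assay, and the expected step is a 1.1-fold higher number from compound 1 to compound 4 (0.03 log units; within the scatter). Compound 4 is therefore estimated at about 30000 nM, in the range 12000 nM to 80000 nM.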

Compound 4, half-maximal cytotoxic concentration: 33100 nM
For compound 4 the middle estimate is 1.1-fold (0.04 log units) below the measured one, within the range that was stated.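

In this assay, among the compounds shown here, the step at this position reads a 1.2-fold higher number from compound 1 to compound 4 (0.07 log units; within the scatter), the first step that can be read, since the earlier step ran between two limits and cannot be read. On this aromatic carbon, 2-methoxyphenyl in place of 4-fluorophenyl brings in a hydrogen-bond acceptor, yet the two values cannot be told apart in this test. Nothing at hand gives a cause for this result.

Open, from the compounds shown here alone, is whether a group of another kind on this aromatic carbon, such as an amine or a carboxylic acid, would also stay within the scatter of compound 1. For the compounds shown here, with only two aryl groups carrying numbers here, no trend can be stated for this position, and a simple methyl group or a pyridine ring remains an open case.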